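A few compounds are considered here, and "the series" means these few. Any claim that something is new, unique, unknown or untested is made for them only; others in the source may bear on it.

Three compounds share a core and differ only in the group that hangs from a saturated chain carbon bound to an aromatic nitrogen. Compound 1 `O=c1ccoc2cc(OCc3cn(Cc4ccccc4)nn3)ccc12` carries an unsubstituted phenyl there. Compound 2 `Cc1ccc(Cn2cc(COc3ccc4c(=O)ccoc4c3)nn2)cc1` carries a 4-methylphenyl. Compound 3 `O=c1ccoc2cc(OCc3cn(Cc4cccc(Br)c4)nn3)ccc12` carries a 3-bromophenyl.

In an ADME assay on L02 cells (Homo sapiens) for cytotoxicity, read by MTT assay, with a stated time of 48 h (a higher number here means a weaker inhibitor, a lower number a stronger inhibitor), compound 1 gives only a limit, > 300000 nM. In this assay compound 2 likewise gives only a limit, > 300000 nM. In this assay compound 3 also gives only a limit, > 300000 nM. Because all three sit at the limit of > 300000 nM in this assay, at which 3 of the 3 values shown sit, none of the steps between them can be read: a step that the two limits leave unreadable from compound 1 to compound 2, a step that the two limits leave unreadable from compound 1 to compound 3 and a step that the two limits leave unreadable from compound 2 to compound 3 all stay hidden behind that limit. Compound 3 therefore stands where every other compound here stands, at the limit and nowhere else on the scale.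

Compound 4 `O=c1ccoc2cc(OCc3cn(Cc4ccc(Cl)cc4Cl)nn3)ccc12` differs from compound 3 in this way: 2,4-dichlorophenyl in place of 3-bromophenyl on a saturated chain carbon bound to an aromatic nitrogen. No measured step bears on this change, since every step shown is unreadable. The step this expectation implies, a number no higher from compound 3 to compound 4 (the limit leaves the size open), is expected to be no movement that can be seen past the limit. Compound 4 is estimated to give 300000 nM in this assay, with a range from 150000 nM to 300000 nM, and most likely only a limit again.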

Compound 4, half-maximal inhibitory concentration: > 300000 nM
Compound 4 gave a limit, no number (the forecaster's own chance of this, stated with the estimate: 85%); the middle value lies on the limit itself.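

Compound 4 gives only a limit in this assay, just as compound 1, compound 2 and compound 3 do, so none of the steps between compound 4 and these three can be read: the limit of > 300000 nM in this assay, at which 4 of the 4 values shown sit.

The compounds shown leave open how these four compare with one another, and whether any group at this place would give a readable number in this assay.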